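Swapping 2-methylbenzyl for 4-(tert-butyl)benzyl

The source may hold more compounds than are shown below. What is called first, only, known or untested is meant among the compounds shown, and "the series" means these compounds.

Measured so far in a functional assay on HepG2 cells (Homo sapiens) for inhibition, read by MTT assay, with a stated time of 72 h; a higher number here means a weaker inhibitor, a lower number a stronger inhibitor:
Compound 1 `O=C1/C(=C\c2ccccc2)c2c(ncn2COCc2ccccc2)CCN1Cc1ccc(-c2ccccc2)cc1` gives 72500 nM
Compound 2 `Cc1ccccc1CN1CCc2ncn(COCc3ccccc3)c2/C(=C/c2ccccc2)C1=O` gives 53300 nM

Only these two numbers exist so far. Compound 2 lies within the scatter of compound 1, so the two cannot be told apart on this read-out.

The next compound is compound 3 `CC(C)(C)c1ccc(CN2CCc3ncn(COCc4ccccc4)c3/C(=C/c3ccccc3)C2=O)cc1`, which keeps the shared core of compound 2 and changes one group: 4-(tert-butyl)phenyl in place of 2-methylphenyl on a saturated chain carbon bound to an amide-type nitrogen in a ring. The same difference, cut one bond further out, reads 2-methylbenzyl to 4-(tert-butyl)benzyl, on a saturated chain carbon bound to an amide-type nitrogen in a ring.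

Within the data shown here, one measured step bears on this, at the same place: a 1.4-fold lower number from compound 1 to compound 2 (0.13 log units; within the scatter). It exchanged 4-phenylphenyl for 2-methylphenyl and stayed inside the scatter. This is a single step, and the data hold no change at this place that moved the number beyond the scatter. No step beyond the scatter is therefore expected in this assay, and the estimated step is a 1.1-fold higher number from compound 2 to compound 3 (0.05 log units; within the scatter). For compound 3 the expected value is 60000 nM, with an estimated range of 30000 nM to 120000 nM.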

Compound 3, half-maximal inhibitory concentration: 18000 nM
Beside the measured number, compound 3's estimate is 3.3-fold (0.52 log units) above it; the measured number lies below the stated range.
By their numbers in this assay, from the lowest: compound 3; then compounds 2 and 1 (each within the scatter of the next).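

In this assay, among these compounds, the group on a saturated chain carbon bound to an amide-type nitrogen in a ring now shows a change beyond the scatter, which the first pair of compounds did not: 4-(tert-butyl)phenyl in place of 2-methylphenyl gives a 3.0-fold lower number from compound 2 to compound 3 (0.47 log units; beyond the scatter). The second reading isolates the aromatic carbon of the same group, where tert-butyl in place of phenyl gives a 4.0-fold lower number from compound 1 to compound 3 (0.61 log units; beyond the scatter), so the read-out responds to what that aromatic carbon carries, and both steps are modest in size. Nothing available accounts for either step.

Going by these compounds, the step from compound 2 to compound 3 removes the methyl group and brings in the tert-butyl group in one change, so the share of each in the step stays open, and a plain benzyl group at this place would be needed to separate them. Also open, on these data alone, is whether an amine or a carboxylic acid in place of tert-butyl on that aromatic carbon would keep the lower number seen for compound 3.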